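Naphthalen-2-yl hydrazone in the benzyl-triazolopyrimidine series

The source may report more compounds than this note shows. Statements on the series, on what has been measured and on what is new or still open speak of the compounds shown alone.

Measured so far in a functional assay on MGC-803 cells (Homo sapiens) for antiproliferative activity, read by MTT assay, with a stated time of 72 h; on this read-out higher numbers stand for weaker inhibition and lower numbers for stronger inhibition:
compound 1 `CCCSc1nc(N/N=C/c2cccnc2)c2nnn(Cc3ccccc3)c2n1` 38100 nM
compound 2 `CCCSc1nc(N/N=C/c2c[nH]c3ccccc23)c2nnn(Cc3ccccc3)c2n1` 7410 nM
compound 3 `CCCSc1nc(N/N=C/c2ccc(Br)cc2)c2nnn(Cc3ccccc3)c2n1` 34900 nM

Compound 3 gives the second highest of the three numbers. Its nearest neighbour is compound 1: a 1.1-fold lower number from compound 1 to compound 3 (0.04 log units; within the scatter), which is within the scatter, so the two cannot be ordered. Compound 2 stands apart: a 4.7-fold higher number from compound 2 to compound 3 (0.67 log units; beyond the scatter).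

Compound 4 `CCCSc1nc(N/N=C/c2ccc3ccccc3c2)c2nnn(Cc3ccccc3)c2n1` is not yet measured. The change from compound 3 is naphthalen-2-yl in place of 4-bromophenyl on a carbon with a double bond to nitrogen.

Going by the values given here, two measured steps bear on this. The step of a 5.1-fold lower number from compound 1 to compound 2 (0.71 log units; beyond the scatter) and the step of a 4.7-fold higher number from compound 2 to compound 3 (0.67 log units; beyond the scatter) both show that the 1H-indol-3-yl group gave a lower number than either of the single six-membered rings, pyridin-3-yl or 4-bromophenyl. Compound 4 also carries two rings at this carbon, but without the ring nitrogen of compound 2, so the same size of change cannot be assumed. A modest lowering of the number in this assay is expected, smaller than the step seen with compound 2.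

For compound 4 the expected value in this assay is 17000 nM, with a range from 6000 nM to 45000 nM. This estimate corresponds to the expected step of a 2.1-fold lower number from compound 3 to compound 4 (0.31 log units; beyond the scatter).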

Compound 4, half-maximal inhibitory concentration: > 64000 nM
Compound 4 was reported as a limit; the forecaster's own chance of this, stated with the estimate: 5%; middle value at least 3.7-fold (0.57 log units) from the limit.
By their numbers in this assay, from the lowest: compound 2; then compounds 3 and 1 (each within the scatter of the next). At a limit, above all of these: compound 4.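

In this assay compound 4 gives a limit and not a number: the limit of > 64000 nM in this assay, at which 1 of the 4 values shown sits.

The naphthalen-2-yl group does not carry over the lower number seen with 1H-indol-3-yl: an at least 8.6-fold higher number from compound 2 to compound 4 (0.93 log units; beyond the scatter). Going by these compounds alone, in this pair, a second ring at the carbon with a double bond to nitrogen is therefore not enough on its own, and the series so far gives the lower number only with the ring that contains nitrogen and two rings together. The other two steps, an at least 1.8-fold higher number from compound 3 to compound 4 (0.26 log units; that floor lies within the scatter) and an at least 1.6-fold higher number from compound 1 to compound 4 (0.22 log units; that floor lies within the scatter), have floors within the scatter, so they cannot place naphthalen-2-yl relative to 4-bromophenyl or pyridin-3-yl, and the limit allows no ordering among these three groups.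

As far as these compounds go, it remains open whether the ring nitrogen with its hydrogen is what separates 1H-indol-3-yl from naphthalen-2-yl, a question that an indol-3-yl with a methyl on that nitrogen or a benzofuran-3-yl group would address. Also open, from the compounds shown here alone, is how a single ring carrying an amine or a carboxylic acid would read at this carbon in the same assay.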